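Cyclobutyl to Cyclopropylmethyl on a Shared Core

A few compounds are considered here, and "the series" means these few. Any claim that something is new, unique, unknown or untested is made for them only; others in the source may bear on it.

Three compounds share one core and differ only in the group on an aromatic carbon of a five-membered aromatic ring with 2 nitrogen. Compound 1 `Cc1nc2ccc(-n3ccc(OCc4ccc(F)cc4)cc3=O)cc2n1C` carries a methyl there, compound 2 `Cn1c(C2CC2)nc2ccc(-n3ccc(OCc4ccc(F)cc4)cc3=O)cc21` a cyclopropyl, and compound 3 `Cn1c(C2CCC2)nc2ccc(-n3ccc(OCc4ccc(F)cc4)cc3=O)cc21` a cyclobutyl. In an assay on CHO cells for displacement of a labelled ligand from melanin-concentrating hormone receptor 1 (Rattus norvegicus), read by scintillation counting, with a stated time of 1 h (a higher number here means a weaker inhibitor, a lower number a stronger inhibitor), compound 1 gives 65 nM, compound 2 gives 28 nM, and compound 3 gives 210 nM. Compound 3 thus shows the highest number of the three: a 3.2-fold higher number from compound 1 to compound 3 (0.51 log units; beyond the scatter) and a 7.5-fold higher number from compound 2 to compound 3 (0.88 log units; beyond the scatter). Compound 4 `Cn1c(CC2CC2)nc2ccc(-n3ccc(OCc4ccc(F)cc4)cc3=O)cc21` is built from compound 3 by cyclopropylmethyl in place of cyclobutyl on an aromatic carbon. Among the compounds with values here, no measured step rearranges a ring group in this way, so the nearest guides are a 7.5-fold higher number from compound 2 to compound 3 (0.88 log units; beyond the scatter) and a 2.3-fold lower number from compound 1 to compound 2 (0.37 log units; beyond the scatter), which show the cyclopropyl giving the lowest number of the groups seen so far and the cyclobutyl the highest. A modest move back toward lower numbers is expected for compound 4, a 1.6-fold lower number from compound 3 to compound 4 (0.21 log units; within the scatter). In this assay compound 4 is estimated at 130 nM, with a range from 45 nM to 400 nM.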

Compound 4, half-maximal inhibitory concentration: 140 nM
The estimate for compound 4 lay 1.1-fold (0.03 log units) below the measured number; low and high end bracket the measured number.
By their numbers in this assay, from the lowest: compound 2; then compound 1; then compounds 4 and 3 (each within the scatter of the next).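

Rejoining the same atoms, from a cyclobutyl into a cyclopropylmethyl, makes no clear difference at this position in this assay, with a 1.5-fold lower number from compound 3 to compound 4 (0.18 log units; within the scatter). The three-membered ring alone therefore does not bring the low number of compound 2: when that ring sits on a saturated chain carbon bound to the aromatic carbon, the result is a 5.0-fold higher number from compound 2 to compound 4 (0.70 log units; beyond the scatter), and, measured against the plain methyl, a 2.2-fold higher number from compound 1 to compound 4 (0.33 log units; beyond the scatter). Nothing available here explains these differences.

From the compounds shown here alone, how an ethyl or an isopropyl at this aromatic carbon would compare with the cyclopropyl of compound 2 remains open, as does the effect of an amine or a longer chain there. Whether the same order of groups would hold with changes elsewhere on the shared core is also unresolved.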